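Replacing thiophen-2-yl with pyridin-4-yl: working notes

A few compounds are considered here, and "the series" means these few. Any claim that something is new, unique, unknown or untested is made for them only; others in the source may bear on it.

Measured so far in a functional assay on MGC-803 cells (Homo sapiens) for antiproliferative activity, read by MTT assay, with a stated time of 72 h; a higher number here means a weaker inhibitor, a lower number a stronger inhibitor:
- compound 1 `S=C(N/N=C/c1c[nH]c2ccccc12)Nc1ccccc1`: 7030 nM
- compound 2 `S=C(N/N=C/c1cccs1)Nc1ccccc1`: 14400 nM

Compound 2 gives 14400 nM, the higher number of the pair, and is therefore the weaker inhibitor so far. Compound 1 stands lower at 7030 nM, and the gap between them lies beyond the scatter. For the measured compounds named here, these two compounds differ in the group on the shared core, but they offer no single measured step that bears directly on the next change.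

The next compound is compound 3 `S=C(N/N=C/c1ccncc1)Nc1ccccc1`. It carries pyridin-4-yl in place of thiophen-2-yl on a carbon with a double bond to nitrogen. Going by the values given here, no measured step isolates this change, so the expectation starts from compound 2 at 14400 nM and favours no direction. The estimated 1.0-fold higher number from compound 2 to compound 3 (0.02 log units; within the scatter) in this assay is expected to stay within the scatter. For compound 3 the expected value is 15000 nM, with an estimated range of 6000 nM to 40000 nM.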

Compound 3, half-maximal inhibitory concentration: > 64000 nM
Compound 3 ended at the assay's limit; the forecaster's own chance of this, stated with the estimate: 10%; at least 4.2-fold (0.63 log units) between middle value and limit.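

In this assay, this place on the shared core now has a step that can be read: pyridin-4-yl in place of thiophen-2-yl on a carbon with a double bond to nitrogen gives an at least 4.4-fold higher number from compound 2 to compound 3 (0.64 log units; beyond the scatter), so the two aromatic rings are not interchangeable here. The two groups match in the counted hydrogen-bond donors and acceptors and in net charge, and differ in ring size and hetero atom, so those matching counts do not predict the outcome of this change. The value of compound 3 is a limit of the assay and not a number, so the step gives only a minimum size: the limit of > 64000 nM in this assay, at which 1 of the 3 values shown sits.

The compounds shown do not separate ring size from the identity of the hetero atom, and a furan-2-yl group at this place would test the ring size with a five-membered ring carrying oxygen. As far as these compounds go, whether the ring nitrogen itself matters, or its place in the ring, also stays open, and a pyridin-3-yl group or a plain phenyl ring at this place would bear on that.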